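The source may hold more compounds than are shown below. What is called first, only, known or untested is meant among the compounds shown, and "the series" means these compounds.

In a functional assay on MDA-MB-231 cells (Homo sapiens) for cytotoxicity, read by MTT assay, with a stated time of 48 h (a higher number here means a weaker inhibitor, a lower number a stronger inhibitor), compound 1 `O=C(NCCCCC(c1ccc(F)cc1)c1ccc(F)cc1)Nc1ccc(C(F)(F)F)cc1` gives 2780 nM. Compound 2 `Cc1cc(Cl)ccc1NC(=O)NCCCCC(c1ccc(F)cc1)c1ccc(F)cc1` gives > 20000 nM, and this is a limit of the assay, not a number. From the compounds shown here alone, compound 2 therefore stands at the limit of > 20000 nM in this assay, at which 1 of the 2 values shown sits, and its true position remains open. Compound 3 `O=C(NCCCCC(c1ccc(F)cc1)c1ccc(F)cc1)Nc1ccc(Br)cc1I` differs from compound 2 at one place: 4-bromo-2-iodophenyl in place of 4-chloro-2-methylphenyl on an amide-type nitrogen. In words, it has 4-bromo-2-iodophenyl in place of 4-chloro-2-methylphenyl on an amide-type nitrogen, while the shared core stays the same. Within the data shown here, only one measured step bears on this change. It is an at least 7.1-fold higher number from compound 1 to compound 2 (0.85 log units; beyond the scatter), made on the same amide-type nitrogen, and it shows that exchanging the aryl group there can shift the read-out in this assay beyond the scatter. That single step does not show how a bromo and iodo pattern will behave, so the direction rests on little evidence. A modest move toward a lower number is the tentative expectation, and a second limit remains quite possible. The expected size is an at least 2.0-fold lower number from compound 2 to compound 3 (0.30 log units; that floor lies within the scatter). Compound 3 is estimated at 10000 nM, with an expected range from 3000 nM to 35000 nM.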

Compound 3, half-maximal inhibitory concentration: > 20000 nM
Compound 3 gave a limit, no number (the forecaster's own chance of this, stated with the estimate: 40%); middle value at least 2.0-fold (0.30 log units) from the limit.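

In this assay, replacing 4-(trifluoromethyl)phenyl with 4-bromo-2-iodophenyl on the amide-type nitrogen gives an at least 7.1-fold higher number from compound 1 to compound 3 (0.85 log units; beyond the scatter), so a second, differently substituted aryl group now separates from compound 1 by a step beyond the scatter. The results for compound 2 and compound 3 are both limits of the assay, not numbers, and the step between them cannot be read, so neither of these two aryl groups can be ranked against the other. What the new result adds is that exchanging 4-chloro-2-methylphenyl for 4-bromo-2-iodophenyl, with its two halogens and no methyl, does not bring a measurable number within the range of the assay, and compound 1 remains the only one of the three to give one: the limit of > 20000 nM in this assay, at which 2 of the 3 values shown sit.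

The compounds shown leave open whether a simpler aryl group on this nitrogen, such as 4-bromophenyl or 4-chlorophenyl, would give a number in this assay. They also leave open how a 2-methyl-4-(trifluoromethyl)phenyl group, or a 4-cyanophenyl group, would compare with the aryl group of compound 1.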